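The compounds below may be only part of what the source reports. "The series", "measured", "known", "first", "only" and "open" are said of these compounds alone.

Compound 1 `Nc1nc(OCC(F)(F)F)c2ncn(/C=C3/CC3(CO)CO)c2n1` is tested in an ADME assay on CCRF-HSB-2 cells (Homo sapiens) for cytotoxicity, with a stated time of 7 days; on this read-out higher numbers stand for lower toxicity in this test and lower numbers for higher toxicity in this test. In this assay compound 1 gives > 20000 nM, which is a limit of the assay and not a number. Compound 2 `Nc1nc(NCc2ccccc2)c2ncn(/C=C3/CC3(CO)CO)c2n1` carries a benzylamino group on the shared core, and in this assay compound 2 gives > 20000 nM, again a limit. Compound 3 `Nc1nc(NC2CCCC2)c2ncn(/C=C3/CC3(CO)CO)c2n1` carries a cyclopentylamino group, and in this assay compound 3 gives > 20000 nM, also a limit. The step that the two limits leave unreadable from compound 1 to compound 2 and the step that the two limits leave unreadable from compound 1 to compound 3 have no readable size, and the same holds for the step that the two limits leave unreadable from compound 2 to compound 3. All three values share (the limit of > 20000 nM in this assay, at which 3 of the 3 values shown sit). Compound 4 `CCCCCCSc1nc(N)nc2c1ncn2/C=C1/CC1(CO)CO` differs from compound 1 in one place: hexylsulfanyl in place of 2,2,2-trifluoroethoxy on an aromatic carbon. The measured steps bear on this change only in that each one ended at the same limit, so neither direction nor size can be drawn from them. The expected step that the limit leaves unreadable from compound 1 to compound 4 is therefore none beyond the scatter, with the assay most likely reporting only its limit again. Compound 4 is estimated at 30000 nM, in a range from 8000 nM to 100000 nM.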

Compound 4, half-maximal cytotoxic concentration: 60000 nM
For compound 4 the middle estimate is 2.0-fold (0.30 log units) below the measured one; the measured number falls inside the stated range.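

Compound 1, compound 2 and compound 3 each stand only at a limit and not at a number, and none of their steps to compound 4 can be read: the limit of > 20000 nM in this assay, at which 3 of the 4 values shown sit. The compounds shown leave open how strongly, and in which direction, swapping these groups on the shared core changes the result in this assay.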